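Trading Trifluoromethyl for Chloro: Compound 3 to Compound 4

The compounds below may be only part of what the source reports. "The series", "measured", "known", "first", "only" and "open" are said of these compounds alone.

Of the compounds shown here, three with a shared core have been tested in a functional assay on NCI-H23 cells (Homo sapiens) for inhibition, read by sulforhodamine B assay, with a stated time of 48 h, tested at 0.1 uM; on this read-out higher numbers stand for a weaker effect at the one concentration tested and lower numbers for a stronger effect. Compound 1 `O=C(Nc1cccc(-n2cc(-c3ccncc3)c(-c3cc(O)cc(Cl)c3)n2)c1)Nc1ccc(Cl)c(C(F)(F)F)c1` gives 91% in this assay. Compound 2 `O=C(Nc1cccc(-n2cc(-c3ccncc3)c(-c3cc(O)cc(Cl)c3)n2)c1)Nc1ccc(Cl)c(Cl)c1` gives 97%. Compound 3 `COc1cc(Cl)cc(-c2nn(-c3cccc(NC(=O)Nc4ccc(Cl)c(C(F)(F)F)c4)c3)cc2-c2ccncc2)c1` gives 90%, the lowest of the three numbers, yet its gaps to compound 1 and to compound 2 both lie within the usual scatter, so none of the three can be set apart from the others.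

Compound 4 `COc1cc(Cl)cc(-c2nn(-c3cccc(NC(=O)Nc4ccc(Cl)c(Cl)c4)c3)cc2-c2ccncc2)c1` has not yet been measured. It differs from compound 3 in one place: chloro in place of trifluoromethyl on an aromatic carbon. The same exchange appears once among the measured pairs: a number 6 percentage points higher from compound 1 to compound 2 (within the scatter). The other measured step, a number 1 percentage points lower from compound 1 to compound 3 (within the scatter), concerns a different place and only fixes the starting point. Because a number 6 percentage points higher from compound 1 to compound 2 (within the scatter) stayed within the scatter, no step beyond the scatter is expected in this assay for compound 4 either, with at most a slight lean toward a higher number. Compound 4 is therefore expected to give 95%, somewhere between 86% and 104%. The expected step, a number 5 percentage points higher from compound 3 to compound 4 (within the scatter), is small enough to count as no change.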

Compound 4, a percentage reported as activity, at one concentration (the size of the read-out at that concentration, not a potency): 93%
Compound 4: middle estimate off by 2 percentage points, on the high side; low and high end bracket the measured number.
By their numbers in this assay, from the lowest: compounds 3, 1, 4 and 2 (each within the scatter of the next).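

In this assay, the exchange of trifluoromethyl for chloro now has a second reading on a second core, a number 3 percentage points higher from compound 3 to compound 4 (within the scatter), so it no longer rests on a single pair, and the two readings agree: the same change on two cores in this assay, a number 6 percentage points higher (within the scatter) from compound 1 to compound 2 and a number 3 percentage points higher (within the scatter) from compound 3 to compound 4, 3 percentage points apart, within the scatter of two such steps

Placing a methyl on the oxygen can also be read a second time, a number 4 percentage points lower from compound 2 to compound 4 (within the scatter), and it too matches its earlier reading: the same change on two cores in this assay, a number 1 percentage points lower (within the scatter) from compound 1 to compound 3 and a number 4 percentage points lower (within the scatter) from compound 2 to compound 4, 3 percentage points apart, within the scatter of two such steps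

Each change therefore looks the same whichever form of the other place it meets, and neither can be told from the scatter at the one concentration tested.

The compounds shown leave open whether a different group at this aromatic carbon, such as an amine, a carboxylic acid or a longer chain, would move the number beyond the scatter. They also leave open whether these two changes would separate at another concentration.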